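Lipophilicity of two chlorinated compounds, and a methyl analogue

The compounds below may be only part of what the source reports. "The series", "measured", "known", "first", "only" and "open" are said of these compounds alone.

- Compound 1 `C=C(c1cccc2ccccc12)C1CCC2(CC1)COC(Nc1ccc(Cl)cc1)OO2` measures 6.15
- Compound 2 `C=C(c1cccc2ccccc12)C1CCC2(CC1)COC(Nc1cc(Cl)cc(Cl)c1)OO2` measures 6.71

In a physicochemical assay for lipophilicity (a higher number here means a more lipophilic compound, a lower number a more polar compound), compound 2 stands highest of the two measured compounds, at 6.71. For the measured compounds named here, the only measured step is a number 0.56 log units higher from compound 1 to compound 2 (beyond the scatter), and it lies beyond the scatter. The next molecule, compound 3 `C=C(c1cccc2ccccc12)C1CCC2(CC1)COC(Nc1ccc(C)cc1)OO2`, keeps the shared core and alters the group on the amine nitrogen: 4-methylphenyl in place of 3,5-dichlorophenyl on an amine nitrogen.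

The measured step bears on this change because it involved the same place on the molecule and gave a number 0.56 log units higher from compound 1 to compound 2 (beyond the scatter). There, 3,5-dichlorophenyl took the place of 4-chlorophenyl. The new change removes 3,5-dichlorophenyl again, so it runs roughly back along that step. However, 4-methylphenyl is not the same group as 4-chlorophenyl, so the earlier step guides the size without fixing it. A fall of similar or slightly larger size, beyond the scatter, is therefore expected in this assay. The estimated change is a number 0.66 log units lower from compound 2 to compound 3 (beyond the scatter). The estimate for compound 3 is 6.05, with an expected range from 5.7 to 6.4.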

Compound 3, partition coefficient: 6.08
Estimate against measurement, compound 3: 0.03 log units below; the measured number falls inside the stated range.
By their numbers in this assay, from the lowest: compounds 3 and 1 (each within the scatter of the next); then compound 2.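

In this assay, the change to 4-methylphenyl from 3,5-dichlorophenyl on the amine nitrogen gives a number 0.63 log units lower from compound 2 to compound 3 (beyond the scatter) and shows that this position responds to a second replacement, not only to the change first measured. The more telling comparison is methyl in place of chloro on an aromatic carbon, which gives a number 0.07 log units lower from compound 1 to compound 3 (within the scatter) and means that compound 1 and compound 3 cannot be told apart in this assay, while compound 2 stands clearly apart from both. The three compounds therefore show what happens at this one position on the shared core, but no measurement here explains why the two groups read alike or why 3,5-dichlorophenyl differs from them.

Still open, on these data alone, is how other groups on this aromatic ring would compare, such as a methoxy group, an amine or a carboxylic acid, which would show whether the close match between chloro and methyl extends to very different substituents. As far as these compounds go, it is also open whether that match would hold if the methyl group were replaced by a longer chain, or if the same swap were made on a different core.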